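This account rests on a few compounds, and the source may have more. Where it says the series, first, only, none or still open, it means among the compounds named here.

Working notes on the series in a functional assay (plasma) for inhibition, with Homo sapiens as the target; a lower number here means a stronger inhibitor, a higher number a weaker inhibitor. Compound 1 `CCCCCCOC[C@@H]1C2CCC(O2)[C@H]1C/C=C\CCCC(=O)O` gives no single number in this assay: its entries read 25000 nM; 18000 nM; 500 nM (3 entries) and disagree widely. Compound 2 `CCC/C=C\COCC1C2CCC(O2)C1C/C=C\CCCC(=O)O` reads 3300 nM, and compound 3 `CCCCCCOC(C)C1C2CCC(O2)C1C/C=C\CCCC(=O)O` reads 14000 nM. Of the two compounds with a single number, compound 2 is the stronger inhibitor, by a margin beyond the scatter. One entry of compound 1 lies under the number of compound 2, and the other two lie well over it.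

Next comes compound 4 `COCC1C2CCC(O2)C1C/C=C\CCCC(=O)O`, not yet measured. The change from compound 2 is hydrogen in place of pent-1-en-1-yl on a saturated chain carbon bound to an oxygen on a saturated carbon. Within the data shown here, no measured pair isolates this change, so its size remains a judgement. Compound 2 at 3300 nM and compound 3 at 14000 nM both keep a chain on the ether oxygen, whereas compound 4 has lost it. The step of a 7.6-fold higher number from compound 2 to compound 4 (0.88 log units; beyond the scatter) is expected to go towards a higher number, a weaker inhibitor, and beyond the scatter. For compound 4 the estimated value is 25000 nM, with an expected range of 7000 nM to 90000 nM.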

Compound 4, half-maximal inhibitory concentration: 22000 nM
For compound 4 the middle estimate is 1.1-fold (0.06 log units) above the measured one, within the range that was stated.
By their numbers in this assay, from the lowest: compound 2; then compounds 3 and 4 (each within the scatter of the next).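

Working notes, continued. In this assay, among these compounds, this is the first direct reading of the position: a 6.7-fold higher number from compound 2 to compound 4 (0.82 log units; beyond the scatter). The step belongs to hydrogen in place of pent-1-en-1-yl on a saturated chain carbon bound to an oxygen on a saturated carbon, and it shows that the group on this carbon counts for inhibition in this pair, with its removal giving a weaker inhibitor by a margin beyond the scatter. The pair gives the direction and size of this one change, but it does not show which feature of pent-1-en-1-yl matters.

Going by these compounds, how ethyl, propyl, phenyl or an amine would read at this place stays open. The effect of a saturated chain also stays open, since compound 1 offers no single number: the several entries of compound 1 in this assay, 25000 nM; 18000 nM; 500 nM (3 entries)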